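The compounds below may be only part of what the source reports. "The series", "measured", "known", "first", "only" and "open" are said of these compounds alone.

Of the compounds shown here, three have so far been measured in an assay on isolated protein for inhibition of MAP kinase-activated protein kinase 5 (Homo sapiens), read by mobility shift assay, tested at 30 uM; a higher number here means more inhibition at the concentration tested (going by the name of the read-out), a lower number less inhibition. Compound 1, with the structure `Nc1n[nH]c2cc(-c3ccncc3)[nH]c(=O)c12`, gives 13%. Compound 2, with the structure `Cc1cc2c(c(N)nn2C)c(N2CCCCC2)n1`, gives 17%. Compound 3, with the structure `Nc1c2c(=O)[nH]c(-c3ccccc3)cc2nn1-c1ccccc1`, gives 22%. That figure is the largest of the three, but the gap to compound 2 and the gap to compound 1 both lie within the usual scatter of repeated measurements, so the three compounds cannot be told apart on these numbers; none of them counts as higher or lower in this assay than the others.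

Compound 4, with the structure `COc1ccc(-c2cc3nn(-c4ccccc4)c(N)c3c(=O)[nH]2)cc1`, has not yet been measured. It differs from compound 3 in one place: methoxy in place of hydrogen on an aromatic carbon. Within the data shown here, no pair of measured compounds shows what such a change does here, so there is no measured step to lean on. With only a small group added and nothing in the measured numbers pointing in either direction, the step is estimated to be small, with no movement beyond the scatter expected: the estimated step is a number 1 percentage points higher from compound 3 to compound 4 (within the scatter). Compound 4 is therefore expected to give about 23%, with a likely range from 8% to 40%.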

Compound 4, a percentage reported as inhibition, at one concentration (the size of the read-out at that concentration, not a potency): 12%
The estimate for compound 4 lay 11 percentage points above the measured number; the measured number falls inside the stated range.
By their numbers in this assay, from the lowest: compounds 4, 1, 2 and 3 (each within the scatter of the next).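

Among these compounds, compound 3 and compound 4 are the first pair here that differ in only one place, so they give the first direct reading of a change at this position: going from phenyl to 4-methoxyphenyl, with the methoxy para to a large group, gives a number 10 percentage points lower from compound 3 to compound 4 (within the scatter) in this assay. That step does not separate the two compounds, so this single pair shows no measurable effect of adding methoxy at this position, and it cannot show a direction for the change. No evidence is available that bears on this result.

As far as these compounds go, it remains open whether a different group at the same place, such as an amine, a carboxylic acid or a fluorine atom, or a longer chain such as ethoxy, would move the number beyond the scatter in either direction. Also open, from the compounds shown here alone, is whether methoxy would read the same on the other phenyl ring of compound 3, and, since each number comes from a single tested concentration, how the potencies of compound 3 and compound 4 compare.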